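Arylsulfonyl series: reading the dichlorophenyl analogue from limits

The compounds below may be only part of what the source reports. "The series", "measured", "known", "first", "only" and "open" are said of these compounds alone.

Compound 3 `O=S(=O)(NC1=NCCN1C(=S)SN1CCn2c1nsc2=S)c1ccc(Br)cc1` stands in a functional assay on KYSE-510 cells (Homo sapiens) for antiproliferative activity, read by crystal violet staining, with a stated time of 96 h (a higher number here means a weaker inhibitor of growth, a lower number a stronger inhibitor of growth), only at a limit of the assay, giving >= 20000 nM. Compound 1 `O=S(=O)(NC1=NCCN1C(=S)SN1CCn2c1nsc2=S)c1ccc(C(F)(F)F)cc1` gives in this assay a limit as well, >= 20000 nM. Compound 2 `COc1cccc(S(=O)(=O)NC2=NCCN2C(=S)SN2CCn3c2nsc3=S)c1` likewise reaches only a limit in this assay, >= 20000 nM. All three rest at the limit of >= 20000 nM in this assay, at which 3 of the 3 values shown sit, so the steps among them stay unread: a step that the two limits leave unreadable from compound 1 to compound 2, a step that the two limits leave unreadable from compound 1 to compound 3 and a step that the two limits leave unreadable from compound 2 to compound 3.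

Compound 4 `O=S(=O)(NC1=NCCN1C(=S)SN1CCn2c1nsc2=S)c1cc(Cl)cc(Cl)c1` differs from compound 3 by 3,5-dichlorophenyl in place of 4-bromophenyl on a sulfonyl sulfur. The steps that bear on this change are those between compound 1, compound 2 and compound 3, each of which the limits leave unreadable, so they give no size and no direction to carry over; within the compounds shown, no aryl change on the sulfonyl sulfur has yet lifted a value off the limit. The step in this assay from compound 3 to compound 4 is therefore expected to be a number no higher from compound 3 to compound 4 (the limit leaves the size open), which means no readable movement. Compound 4 is estimated at 20000 nM in this assay, within a range from 8000 nM to 50000 nM, most likely reported again only as a limit.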

Compound 4, concentration for 50% growth inhibition: >= 20000 nM
Compound 4: a limit, no number (the forecaster's own chance of this, stated with the estimate: 85%); the middle value sits exactly at the limit.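

Compound 4 gives only a limit in this assay, so its steps from compound 1, compound 2 and compound 3 cannot be read: the limit of >= 20000 nM in this assay, at which 4 of the 4 values shown sit.

The compounds shown leave open whether any aryl group on the sulfonyl sulfur can bring a value off this limit.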